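The source may hold more compounds than are shown below. What is called first, only, known or untested is meant among the compounds shown, and "the series" means these compounds.

Measured so far in a functional assay for agonist activity at G protein-coupled receptor 88 (Homo sapiens), read by HTRF and cAMP accumulation; a higher number here means that more compound is needed for the effect, a lower number that less compound is needed:
compound 1 `CC[C@H](C)[C@H](N)CN(C(=O)[C@@H]1C[C@H]1c1cccc(OC)c1)c1ccc(-c2ccccc2)cc1` gives 3000 nM;
compound 2 `CC[C@H](C)[C@H](N)CN(C(=O)[C@@H]1C[C@H]1c1ccc(F)cc1)c1ccc(-c2ccccc2)cc1` gives 600 nM;
compound 3 `CC(C)C[C@H](N)CN(C(=O)[C@@H]1C[C@H]1c1ccccc1)c1ccc(-c2ccsc2)cc1` gives 1200 nM.

Compound 3 sits close to compound 2: the two numbers lie within the usual scatter of each other, so no order can be read between them. Compound 1, by contrast, gives a higher number than compound 3, and that gap is beyond the scatter.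

Compound 4 `COc1cccc(-c2ccc(N(C[C@@H](N)CC(C)C)C(=O)[C@@H]3C[C@H]3c3ccccc3)cc2)c1` differs from compound 3 in one place: 3-methoxyphenyl in place of thiophen-3-yl on an aromatic carbon. Going by the values given here, the only measured step, a 5.0-fold lower number from compound 1 to compound 2 (0.70 log units; beyond the scatter), concerns a different position, so no step bears directly on this change. The expectation is therefore a step no larger than the scatter, a 1.3-fold higher number from compound 3 to compound 4 (0.10 log units; within the scatter), and compound 4 is estimated at 1500 nM, between 500 nM and 5000 nM.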

Compound 4, half-maximal effective concentration: 1100 nM
Beside the measured number, compound 4's estimate is 1.4-fold (0.13 log units) above it; low and high end bracket the measured number.
By their numbers in this assay, from the lowest: compounds 2, 4 and 3 (each within the scatter of the next); then compound 1.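

Going by these compounds alone, the step of a 1.1-fold lower number from compound 3 to compound 4 (0.04 log units; within the scatter) is the first look at this place, on an aromatic carbon para to a large group, and it shows no readable change. The five-membered thiophen-3-yl ring and the larger, six-membered 3-methoxyphenyl ring therefore serve equally well here, even though one carries sulfur in the ring and the other a methoxy group. Nothing measured on these compounds explains why the swap leaves the number unchanged. Both groups are uncharged aromatic rings, so the compounds shown leave open whether a ring bearing a carboxylic acid or an amine would fare the same. As far as these compounds go, a small non-aromatic group such as methyl at this place also remains untested by these compounds.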